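Amide in Place of Acid on a Glutathione S-Transferase Inhibitor

The compounds below may be only part of what the source reports. "The series", "measured", "known", "first", "only" and "open" are said of these compounds alone.

Compound 1 `O=C(O)CCC(=O)OCCCCCCSc1ccc([N+](=O)[O-])c2nonc12`: 530 nM
Compound 2 `O=C(CCC(=O)OCCCCCCSc1ccc([N+](=O)[O-])c2nonc12)Nc1cccc(Cl)c1`: 28800 nM
Compound 3 `COc1ccc(NC(=O)CCC(=O)OCCCCCCSc2ccc([N+](=O)[O-])c3nonc23)cc1OC`: 6470 nM

In an assay on isolated protein for inhibition of glutathione S-transferase P (Homo sapiens), with a stated time of 10 min (a higher number here means a weaker inhibitor, a lower number a stronger inhibitor), compound 1 holds the lowest number of the three, with compound 3 nearest a 12-fold higher number from compound 1 to compound 3 (1.09 log units; beyond the scatter) and compound 2 furthest a 54-fold higher number from compound 1 to compound 2 (1.74 log units; beyond the scatter). Compound 4 `CN(C)CCCNC(=O)CCC(=O)OCCCCCCSc1ccc([N+](=O)[O-])c2nonc12` differs from compound 1 by (3-(dimethylamino)propyl)amino in place of hydroxy on a carbonyl carbon. The two measured steps that bear on this both replace the hydroxy on the same carbonyl carbon with an amine: a 54-fold higher number from compound 1 to compound 2 (1.74 log units; beyond the scatter) and a 12-fold higher number from compound 1 to compound 3 (1.09 log units; beyond the scatter), each large and each in the direction of a weaker inhibitor. The entering group in compound 4 carries no ring, unlike those in compound 2 and compound 3, so the size is less certain, but the direction is expected to repeat. Compound 4 is therefore expected to show a 9.4-fold higher number from compound 1 to compound 4 (0.97 log units; beyond the scatter), estimated at 5000 nM with a range of 1500 nM to 20000 nM.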

Compound 4, half-maximal inhibitory concentration: 160 nM
The estimate for compound 4 lay 31-fold (1.49 log units) above the measured number, outside the stated range (below it).
By their numbers in this assay, from the lowest: compound 4; then compound 1; then compound 3; then compound 2.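

In this assay, replacing the hydroxy on this carbonyl carbon need not weaken inhibition: with (3-(dimethylamino)propyl)amino the direction reverses, giving a 3.3-fold lower number from compound 1 to compound 4 (0.52 log units; beyond the scatter). What sits on the amide-type nitrogen therefore decides the outcome, as 3-(dimethylamino)propyl in place of the aromatic groups gives a 40-fold lower number from compound 3 to compound 4 (1.61 log units; beyond the scatter) and a 180-fold lower number from compound 2 to compound 4 (2.26 log units; beyond the scatter). Nothing measured here accounts for this reversal.

The compounds shown leave open whether the gain depends on the dimethylamino group, which a plain propyl chain on the same nitrogen would test. They also leave open whether a longer chain leading to that amine would keep it.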